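The source may report more compounds than this note shows. Statements on the series, on what has been measured and on what is new or still open speak of the compounds shown alone.

Among the compounds with values here, compound 2 `O=C(OC1(C(=O)Nc2ccc([N+](=O)[O-])cc2)CCCCC1)c1ccccc1I` is one of two compounds measured in an ADME assay on WI-38 cells (Homo sapiens) for inhibition, read by MTT assay, with a stated time of 72 h; a lower number here means a stronger inhibitor, a higher number a weaker inhibitor: compound 2 gives 396 nM, and compound 1 `Cc1ccccc1C(=O)OC1(C(=O)Nc2ccc([N+](=O)[O-])cc2)CCCCC1` gives 352 nM, the step of a 1.1-fold higher number from compound 1 to compound 2 (0.05 log units; within the scatter) lying within the scatter. Compound 3 `CCOC(=O)c1ccccc1C(=O)OC1(C(=O)Nc2ccc([N+](=O)[O-])cc2)CCCCC1` alters compound 2 by ethoxycarbonyl in place of iodo on an aromatic carbon. Within the data shown here, the only step that bears on this aromatic carbon is a 1.1-fold higher number from compound 1 to compound 2 (0.05 log units; within the scatter), which left the number flat, and no measured step covers an ethoxycarbonyl, so no shift beyond the scatter is expected. Compound 3 is expected to give 400 nM, with a range from 200 nM to 800 nM. The expected step is a 1.0-fold higher number from compound 2 to compound 3 (0.00 log units; within the scatter).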

Compound 3, half-maximal inhibitory concentration: 386 nM
Beside the measured number, compound 3's estimate is 1.0-fold (0.02 log units) above it, within the range that was stated.
By their numbers in this assay, from the lowest: compounds 1, 3 and 2 (each within the scatter of the next).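

In this assay this aromatic carbon also accepts ethoxycarbonyl, with five heavy atoms and two hydrogen-bond acceptors, without a shift beyond the scatter (a 1.0-fold lower number from compound 2 to compound 3 (0.01 log units; within the scatter); a 1.1-fold higher number from compound 1 to compound 3 (0.04 log units; within the scatter)). Methyl, iodo and ethoxycarbonyl thus give numbers within the scatter of one another, so neither heavy-atom count nor acceptor count tracks the read-out across compounds 1, 2 and 3. No available evidence accounts for this flat result. Going by these compounds, whether an amine or a carboxylic acid on this carbon would move the number remains open. So does the effect of changes elsewhere on the shared core.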